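The source may report more compounds than this note shows. Statements on the series, on what has been measured and on what is new or still open speak of the compounds shown alone.

Measured so far in an assay on CHO cells for antagonist activity at transient receptor potential cation channel subfamily V member 1 (Homo sapiens), read by FLIPR; a lower number here means a stronger inhibitor, a higher number a weaker inhibitor:
- compound 1 `CC1CCN(c2nc(C(F)F)ccc2CNC(=O)C(C)c2ccc(NS(C)(=O)=O)c(F)c2)CC1`: 1 nM
- compound 2 `CC1CCN(c2nc(-c3ccc(F)cc3)ccc2CNC(=O)C(C)c2ccc(NS(C)(=O)=O)c(F)c2)CC1`: 59 nM
- compound 3 `CC(C(=O)NCc1ccc(C(F)(F)Cl)nc1N1CCCCCC1)c1ccc(NS(C)(=O)=O)c(F)c1`: 0.5 nM

Compound 3 gives the lowest of the three numbers in this assay. Compound 1 sits within the scatter of compound 3, so no order between them is claimed. Within the data shown here, compound 2 is far from both; the only single-point step measured, a 59-fold higher number from compound 1 to compound 2 (1.77 log units; beyond the scatter), is a large loss and concerns the chloro(difluoro)methyl side of the core, not the amine position.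

Compound 4 `CC(C(=O)NCc1ccc(C(F)(F)Cl)nc1OCc1ccccn1)c1ccc(NS(C)(=O)=O)c(F)c1` differs from compound 3 by (pyridin-2-yl)methoxy in place of azepan-1-yl on an aromatic carbon. Among the measured compounds shown here, no measured step touches this position: every compound measured so far carries a saturated amine ring there, so the measured data give no direct guide to what this exchange does. The step from compound 1 to compound 2 only shows that a single change on the core can move the number a long way.

The expectation for compound 4 is therefore wide. A weaker number than compound 3 is expected, with the step estimated at a 16-fold higher number from compound 3 to compound 4 (1.20 log units; beyond the scatter), on the ground that the exchange removes a group shared by all three measured compounds. The estimate for compound 4 in this assay is 8 nM, with a range from 1 nM to 80 nM.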

Compound 4, inhibition constant: 4.2 nM
For compound 4 the middle estimate is 1.9-fold (0.28 log units) above the measured one, within the range that was stated.
By their numbers in this assay, from the lowest: compounds 3 and 1 (each within the scatter of the next); then compound 4; then compound 2.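

In this assay, the exchange gives an 8.4-fold higher number from compound 3 to compound 4 (0.92 log units; beyond the scatter), a modest loss, and compound 4 still reads 4.2 nM, so a saturated amine ring is not required at this position for a low number in the series. Among these compounds, the position accepts (pyridin-2-yl)methoxy, which replaces a seven-membered non-aromatic ring with a six-membered aromatic ring carrying one hetero atom and adds an oxygen, yet the single step cannot separate the effects of these differences. No measurement is available that explains the size of this step.

Still open, going by these compounds, is which part of (pyridin-2-yl)methoxy sets the number: benzyloxy at this carbon would test the pyridine nitrogen, (pyridin-3-yl)methoxy its location, and 2-(pyridin-2-yl)ethoxy a longer chain. Also open, on these data alone, is whether the step from azepan-1-yl to (pyridin-2-yl)methoxy keeps its size when difluoromethyl takes the place of chloro(difluoro)methyl on the shared core.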